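From 2,4-dimethylphenyl to 3,5-dimethylphenyl: expected solubility

The source may report more compounds than this note shows. Statements on the series, on what has been measured and on what is new or still open speak of the compounds shown alone.

- Compound 1 `COc1cccc(F)c1-c1nc(CN2CCC(C(=O)NCCCN3C[C@H](C)C[C@H](C)C3)CC2)c(C)o1`: > 74 ug/mL
- Compound 2 `Cc1ccc(-c2nc(CN3CCC(C(=O)NCCCN4C[C@H](C)C[C@H](C)C4)CC3)c(C)o2)c(C)c1`: > 71 ug/mL

In a physicochemical assay for solubility, in phosphate buffer, measured as kinetic solubility, at pH 7.4 (a higher number here means a more soluble compound, a lower number a less soluble compound), compound 2 gives > 71 ug/mL, which is a limit and not a number. Compound 1 gives > 74 ug/mL, which is also a limit. Compound 3 `Cc1cc(C)cc(-c2nc(CN3CCC(C(=O)NCCCN4C[C@H](C)C[C@H](C)C4)CC3)c(C)o2)c1` has the same atoms as compound 2, joined differently: 3,5-dimethylphenyl in place of 2,4-dimethylphenyl on an aromatic carbon. Among the measured compounds shown here, the one measured step that bears on this is a step that the two limits leave unreadable from compound 1 to compound 2, and it offers no size to carry over. No step beyond the scatter is therefore expected in this assay, and no direction is favoured. The expected step is an at least 1.0-fold lower number from compound 2 to compound 3 (0.00 log units; that floor lies within the scatter). The estimate for compound 3 is 70 ug/mL, with an expected range of 35 ug/mL to 85 ug/mL.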

Compound 3, solubility: > 71 ug/mL
Compound 3 gave a limit, no number (the forecaster's own chance of this, stated with the estimate: 70%); at least 1.0-fold (0.00 log units) between middle value and limit.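

In this assay, among the compounds shown here, compound 1, compound 2 and compound 3 each give a limit and not a number, and no step between them can be read. As far as these compounds go, whether 2-fluoro-6-methoxyphenyl, 2,4-dimethylphenyl and 3,5-dimethylphenyl differ at all in this assay stays open.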